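The compounds below may be only part of what the source reports. "The series", "measured", "known", "first", "only" and "open" are said of these compounds alone.

Compound 3 `CC(Cc1ccc(NCc2cccc(Oc3ccccc3)c2)cc1)C(=O)O` stands second highest of the three compounds measured in a functional assay on CHO cells for agonist activity at Free fatty acid receptor 1 (Homo sapiens), read by a luciferase reporter (a higher number here means a larger maximal response, a lower number a smaller maximal response), where compound 3 gives 70%. Its nearest neighbour is compound 2 `Cc1nc(-c2ccc(C(F)(F)F)cc2)sc1CNc1ccc(OCC(=O)O)cc1`, which in this assay reaches 100%, and the furthest is compound 1 `Cc1nc(-c2ccc(C(F)(F)F)cc2)sc1CNc1ccc(CC(=O)O)cc1`, which in this assay gives 18%. The single measured step among these compounds is a number 82 percentage points higher from compound 1 to compound 2 (beyond the scatter).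

Compound 4 `CN(C)C(=O)CCc1ccc(NCc2cccc(Oc3ccccc3)c2)cc1` has not yet been measured. It differs from compound 3 by (dimethylcarbamoyl)methyl in place of 1-carboxyethyl on a saturated chain carbon bound to an aromatic carbon. The measured step from compound 1 to compound 2 swaps carboxymethyl for carboxymethoxy, so both ends of that step keep the same carboxy end, while the change to compound 4 trades the carboxy for a dimethylcarbamoyl. For the measured compounds named here, no measured pair here makes such a trade, so nothing measured bears directly on it, and the expectation rests on the structural change alone, with wide uncertainty. The step in this assay is expected to be a number 35 percentage points lower from compound 3 to compound 4 (beyond the scatter), a drop beyond the scatter. Compound 4 is estimated to give 35% in this assay, within a range from 5% to 75%.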

Compound 4, largest response reached (reported as percent of maximum), in percent of the reference or control that the assay uses: 50%
Beside the measured number, compound 4's estimate is 15 percentage points below it, and the stated range covers the measured number.
By their numbers in this assay, from the lowest: compound 1; then compound 4; then compound 3; then compound 2.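

In this assay, (dimethylcarbamoyl)methyl in place of 1-carboxyethyl on a saturated chain carbon bound to an aromatic carbon gives a number 20 percentage points lower from compound 3 to compound 4 (beyond the scatter), so this change lowers the maximal response, yet compound 4 still reaches 50%. All three earlier compounds end in a carboxy group, so they could not show what happens without one; compound 4 shows that, on this shared core, a clear response remains when a dimethylcarbamoyl group stands in its place. Nothing available explains the size of this step.

The swap changes two things at once, since it replaces the carboxy group with a dimethylcarbamoyl group and also removes the methyl carried by 1-carboxyethyl, so the compounds shown leave open how much of the step belongs to each part. A 2-(dimethylcarbamoyl)propyl chain, which keeps that methyl, would separate the two, while a plain carboxamide or a methyl ester at the same chain end would show whether the response depends on the particular group that replaces the carboxy group.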